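A few compounds are considered here, and "the series" means these few. Any claim that something is new, unique, unknown or untested is made for them only; others in the source may bear on it.

Compounds 1, 2 and 3 share one core and differ only in the group on a nitrogen on an aromatic ring. In an ADME assay on A549 cells (Homo sapiens) for cytotoxicity, read by resazurin assay, with a stated time of 48 h (on this read-out higher numbers stand for lower toxicity in this test and lower numbers for higher toxicity in this test), compound 1 `O=C(Nc1ccc(NC2CCCCC2)cc1Cl)c1cc(Cl)ccc1O` gives 68300 nM, compound 2 `O=C(Nc1ccc(NCc2ccccc2)cc1Cl)c1cc(Cl)ccc1O` gives 19700 nM, and compound 3 `O=C(Nc1ccc(NCc2ccc(Br)cc2)cc1Cl)c1cc(Cl)ccc1O` gives 40900 nM, the second highest of the three numbers. The step of a 2.1-fold higher number from compound 2 to compound 3 (0.32 log units; beyond the scatter) shows the effect of adding bromo, while a 1.7-fold lower number from compound 1 to compound 3 (0.22 log units; within the scatter) stays within the scatter. Compound 4 `O=C(Nc1ccc(NCc2ccc(O)nc2)cc1Cl)c1cc(Cl)ccc1O` changes the outer group: 6-hydroxypyridin-3-yl in place of 4-bromophenyl on a saturated chain carbon bound to a nitrogen on an aromatic ring. Within the data shown here, no measured step covers such an exchange. Among the measured compounds shown here, the only related step, a 2.1-fold higher number from compound 2 to compound 3 (0.32 log units; beyond the scatter), suggests that losing the bromo may move the number back toward compound 2. Compound 4 is therefore expected to show a modest lower number, a 1.4-fold lower number from compound 3 to compound 4 (0.13 log units; within the scatter). Compound 4 is estimated at 30000 nM, with a range from 10000 nM to 90000 nM.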

Compound 4, half-maximal cytotoxic concentration: 98500 nM
For compound 4 the middle estimate is 3.3-fold (0.52 log units) below the measured one; measured number outside the range, above it.
By their numbers in this assay, from the lowest: compound 2; then compounds 3, 1 and 4 (each within the scatter of the next, the first and the last beyond it).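

Changing the outer ring at this place moves the number in this assay: 6-hydroxypyridin-3-yl in place of 4-bromophenyl gives (a 2.4-fold higher number from compound 3 to compound 4 (0.38 log units; beyond the scatter)), and in place of phenyl it gives (a 5.0-fold higher number from compound 2 to compound 4 (0.70 log units; beyond the scatter)). So removing the bromo need not bring the number back toward compound 2 when the new ring carries a nitrogen and a hydroxy group, while the exchange for cyclohexyl stays within the scatter (a 1.4-fold higher number from compound 1 to compound 4 (0.16 log units; within the scatter)). No measurement here explains these steps. The compounds shown leave open whether plain pyridin-3-yl or 4-hydroxyphenyl would give the same number, so the ring nitrogen and the hydroxy group cannot yet be told apart.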